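Trimming the Sulfonyl Aryl: Bromothiophene in Place of Benzothiophene

This account rests on a few compounds, and the source may have more. Where it says the series, first, only, none or still open, it means among the compounds named here.

Compound 1, `CCN(C/C=C/C#CC(C)(C)C)Cc1cccc(OCCN(C)S(=O)(=O)c2cccs2)c1`: 60 nM
Compound 2, `CCN(C/C=C/C#CC(C)(C)C)Cc1cccc(OCCN(C)S(=O)(=O)c2cc3ccccc3s2)c1`: 1800 nM

Both measured compounds share a core and differ only in the aromatic group on the sulfonyl sulfur. In a functional assay on HepG2 cells for inhibition of squalene monooxygenase (Homo sapiens) (a higher number here means a weaker inhibitor, a lower number a stronger inhibitor), compound 1 gives 60 nM, and compound 2 gives 1800 nM. Among the measured compounds shown here, compound 2 thus carries the highest of the two numbers; its only neighbour is compound 1, and the step between them, a 30-fold higher number from compound 1 to compound 2 (1.48 log units; beyond the scatter), is large and well beyond the scatter.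

Compound 3, `CCN(C/C=C/C#CC(C)(C)C)Cc1cccc(OCCN(C)S(=O)(=O)c2ccc(Br)s2)c1`, keeps the core and changes the same group once more: 5-bromothiophen-2-yl in place of 1-benzothiophen-2-yl on a sulfonyl sulfur. For the measured compounds named here, the one measured step that bears on this change is a 30-fold higher number from compound 1 to compound 2 (1.48 log units; beyond the scatter), which shows that enlarging the thiophene to a benzothiophene at this position raised the number sharply. Going from compound 2 to compound 3 reverses much of that enlargement while adding a bromine to the smaller ring. On this basis compound 3 is expected to move back toward the number of compound 1, with an estimated step of a 9.0-fold lower number from compound 2 to compound 3 (0.95 log units; beyond the scatter). Compound 3 is therefore estimated at 200 nM in this assay, within a range of 60 nM to 700 nM.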

Compound 3, half-maximal inhibitory concentration: 390 nM
The estimate for compound 3 lay 2.0-fold (0.29 log units) below the measured number, and the stated range covers the measured number.
By their numbers in this assay, from the lowest: compound 1; then compound 3; then compound 2.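

In this assay, compound 3 gives the first view of a substituent on the thiophene that is not a fused ring. With a 6.5-fold higher number from compound 1 to compound 3 (0.81 log units; beyond the scatter), bromo in place of hydrogen on an aromatic carbon is a modest weakening on its own, and beyond the scatter. Exchanging the fused ring for the bromine, a 4.6-fold lower number from compound 2 to compound 3 (0.66 log units; beyond the scatter), recovers only part of the ground lost in a 30-fold higher number from compound 1 to compound 2 (1.48 log units; beyond the scatter), so among these three compounds both additions to the plain thiophen-2-yl on the sulfonyl sulfur raise the number, the 1-benzothiophen-2-yl by more than the bromine. Nothing available explains why either group weakens inhibition.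

From the compounds shown here alone, what stays open is whether this weakening belongs to bromine itself or extends to other groups in its place, such as chloro, fluoro, methyl or nitrile on the thiophene. It is equally unclear whether any aryl on the sulfonyl sulfur can match the plain thiophen-2-yl of compound 1, for example an unsubstituted phenyl or a furan-2-yl.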